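The source may report more compounds than this note shows. Statements on the series, on what has been measured and on what is new or still open speak of the compounds shown alone.

Measured compounds in the series:
- compound 1, `O=C(O)c1cccc(Cc2c(C3CC3)nn3cc(Cl)ccc23)n1`: 1500 nM
- compound 2, `O=C(O)c1cccc(Cc2c(N3CCCCC3)nn3cc(Cl)ccc23)n1`: 79 nM

For the measured compounds named here, compound 2 gives the lowest of the two numbers in a functional assay on cells for antagonist activity at prostaglandin E2 receptor EP1 subtype (Rattus norvegicus), read by fluorescence and calcium flux, with a stated time of 60 s; a lower number here means a stronger inhibitor, a higher number a weaker inhibitor; the nearest is compound 1, and the only measured step, a 19-fold lower number from compound 1 to compound 2 (1.28 log units; beyond the scatter), separates them clearly. That step exchanges cyclopropyl for piperidin-1-yl on the shared core.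

Compound 3, `O=C(O)c1cccc(Cc2c(N3CCCCCC3)nn3cc(Cl)ccc23)n1`, has not been measured. It differs from compound 2 by azepan-1-yl in place of piperidin-1-yl on an aromatic carbon. The measured step bears on this change only loosely: it replaces cyclopropyl with a nitrogen-linked ring, whereas the change to compound 3 keeps the nitrogen-linked ring and enlarges it. Going by the values given here, no measured pair shows how ring size at this place affects this assay, so nothing supports a large move in either direction.

The expected step is therefore a 1.0-fold higher number from compound 2 to compound 3 (0.01 log units; within the scatter), within the scatter, with compound 3 estimated close to compound 2. For compound 3 the estimate in this assay is 80 nM, with a range from 30 nM to 250 nM.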

Compound 3, half-maximal inhibitory concentration: 1400 nM
Beside the measured number, compound 3's estimate is 18-fold (1.24 log units) below it, and the stated range ends below it.
By their numbers in this assay, from the lowest: compound 2; then compounds 3 and 1 (each within the scatter of the next).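

In this assay the size of the nitrogen-linked ring at this place matters sharply: with azepan-1-yl in place of piperidin-1-yl, the seven-membered ring gives an 18-fold higher number from compound 2 to compound 3 (1.25 log units; beyond the scatter) in a single change. Taken alone, the earlier step could be read as a gain from any nitrogen-linked ring on this aromatic carbon, but a 1.1-fold lower number from compound 1 to compound 3 (0.03 log units; within the scatter) removes that reading, so among the groups shown the low number belongs to piperidin-1-yl alone and not to nitrogen attachment as such. No measurement to hand accounts for this dependence on ring size.

The compounds shown leave open whether the six-membered ring marks a narrow optimum or simply the upper limit of what this place accepts, a question that pyrrolidin-1-yl, the five-membered ring, would help to settle. They also leave open whether the result depends on an all-carbon ring, which morpholin-4-yl would test at the same ring size, and whether an open-chain amine such as diethylamino behaves like piperidin-1-yl or like azepan-1-yl.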